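Removing one chloro group from compound 2

The source may report more compounds than this note shows. Statements on the series, on what has been measured and on what is new or still open speak of the compounds shown alone.

In a functional assay on HepG2 cells (Homo sapiens) for inhibition, read by MTT assay, with a stated time of 72 h (a lower number here means a stronger inhibitor, a higher number a weaker inhibitor), compound 1 `C=C(c1ccc(Cl)c(Cl)c1)C1COC2(CCCCC2)OO1` gives 83500 nM. Compound 2 `C=C(c1ccc(Cl)c(Cl)c1Cl)C1COC2(CCCC2)OO1` gives 8450 nM, the lower of the two numbers and beyond the scatter of the other. Compound 3 `C=C(c1ccc(Cl)cc1Cl)C1COC2(CCCC2)OO1` is still unmeasured. It carries hydrogen in place of chloro on an aromatic carbon, ortho to two chloro groups and meta to a large group: hydrogen in place of chloro on an aromatic carbon. Within the data shown here, no measured pair isolates this change, so the expectation is loose. A modest rise is expected, estimated as a 2.1-fold higher number from compound 2 to compound 3 (0.33 log units; beyond the scatter). The estimated value for compound 3 is 18000 nM, with an expected range of 5000 nM to 60000 nM.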

Compound 3, half-maximal inhibitory concentration: 15700 nM
Estimate against measurement, compound 3: 1.1-fold (0.06 log units) above; the measured number falls inside the stated range.
By their numbers in this assay, from the lowest: compounds 2 and 3 (each within the scatter of the next); then compound 1.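

Among these compounds, this is the only single-place comparison so far. With hydrogen in place of chloro on this aromatic carbon, ortho to two chloro groups, this assay gives a 1.9-fold higher number from compound 2 to compound 3 (0.27 log units; within the scatter) and so shows no measurable dependence on this chloro group. Nothing measured beyond these numbers bears on the result.

Still open, going by these compounds, is how a methoxy group or an amine on this aromatic carbon would read. Also open, on these data alone, is whether the same exchange behaves alike on the core of compound 1.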